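A few compounds are considered here, and "the series" means these few. Any claim that something is new, unique, unknown or untested is made for them only; others in the source may bear on it.

Working notes on the series. Compound 1 `CN1CCN(CCCOc2cccc3nc(Nc4ccc(Cl)c(C(F)(F)F)c4)ccc23)CC1` and compound 2 `CN1CCN(CCCOc2cccc3nc(Nc4ccc(Cl)c(F)c4)ccc23)CC1` share one core and differ only in the substituent pattern of the anilino ring. In a functional assay on cells (Panel prostate (Carcinoma cell lines), Homo sapiens) for inhibition, read by sulforhodamine B assay, with a stated time of 48 h (a higher number here means that more compound is tolerated, a lower number that less compound is tolerated), compound 1 gives 5880 nM, and in the same assay compound 2 gives 6210 nM. Within the data shown here, the only step recorded so far, a 1.1-fold higher number from compound 1 to compound 2 (0.02 log units; within the scatter), is a fluoro in place of trifluoromethyl on an aromatic carbon and does not move the number beyond the scatter. On the numbers shown, compound 2 therefore stands alongside compound 1, the two values separated by a gap that is within the scatter, with no other neighbours to place it against.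

Compound 3 `CN1CCN(CCCOc2cccc3nc(Nc4ccc(F)c(F)c4)ccc23)CC1` is the next member: relative to compound 2 the change is fluoro in place of chloro on an aromatic carbon, a halogen exchange on the same ring that carried the earlier exchange. Among the measured compounds shown here, the one step that bears on it, a 1.1-fold higher number from compound 1 to compound 2 (0.02 log units; within the scatter), was flat, so for compound 3 no step beyond the scatter is expected in this assay in either direction. The expected step of a 1.0-fold lower number from compound 2 to compound 3 (0.00 log units; within the scatter) is flat. Compound 3 is estimated at 6200 nM, with a range from 3000 nM to 13000 nM.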

Compound 3, concentration lethal to 50% of the cells: 18000 nM
Compound 3: middle estimate off by 2.9-fold (0.46 log units), on the low side; the measured number lies above the stated range.
By their numbers in this assay, from the lowest: compounds 1 and 2 (each within the scatter of the next); then compound 3.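

In this assay, among these compounds, the exchange of chloro for fluoro, on the aromatic carbon para to a large group and ortho to a fluoro group, gives a 2.9-fold higher number from compound 2 to compound 3 (0.46 log units; beyond the scatter) and is the first change to move the number beyond the scatter, whereas the exchange of trifluoromethyl for fluoro on the same ring gave a 1.1-fold higher number from compound 1 to compound 2 (0.02 log units; within the scatter) and stayed within it. Replacing the whole 4-chloro-3-(trifluoromethyl)phenyl group with 3,4-difluorophenyl gives a 3.1-fold higher number from compound 1 to compound 3 (0.49 log units; beyond the scatter) and is also modest, so among these three compounds the only shift beyond the scatter comes with the loss of chloro, and more compound is tolerated once it has gone. Nothing available bears on the reason for this shift.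

The compounds shown leave open whether the rise belongs to fluoro itself or to the removal of chloro, which a bromo, methyl, methoxy or nitrile group, or plain hydrogen, at the same place would help to separate. They also leave open whether the same exchange gives a similar step when the trifluoromethyl group is kept on the ring.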